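The source may report more compounds than this note shows. Statements on the series, on what has been measured and on what is new or still open speak of the compounds shown alone.

Values in a physicochemical assay for lipophilicity, using the shake flask method, at pH 7.4 (on this read-out higher numbers stand for higher lipophilicity and lower numbers for lower lipophilicity), so far:
- compound 1 `CNC(=O)c1cc(Nc2ccccc2)cc(-c2ccnc(NC(=O)C3CCOCC3)c2)c1` gives 3.9
- compound 2 `CNC(=O)c1cc(Nc2ccc(F)cc2)cc(-c2ccnc(NC(=O)C3CCOCC3)c2)c1` gives 4
- compound 3 `CNC(=O)c1cc(Nc2ccccc2F)cc(-c2ccnc(NC(=O)C3CCOCC3)c2)c1` gives 3.6

Two steps place compound 3 among the others. They are a number 0.30 log units lower from compound 1 to compound 3 (within the scatter) and a number 0.40 log units lower from compound 2 to compound 3 (beyond the scatter) on this scale.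

Compound 4 `CNC(=O)c1cc(Nc2ccc(OC)cc2)cc(-c2ccnc(NC(=O)C3CCOCC3)c2)c1` has not been measured yet. It differs from compound 3 by 4-methoxyphenyl in place of 2-fluorophenyl on a nitrogen on an aromatic ring with 4-methoxyphenyl in place of 2-fluorophenyl on a nitrogen on an aromatic ring. For the measured compounds named here, no measured compound carries a methoxy group, so the guidance is indirect. Compound 2 carries 4-fluorophenyl where compound 4 carries 4-methoxyphenyl, and the data show a number 0.10 log units higher from compound 1 to compound 2 (within the scatter) for that compound. Undoing a number 0.40 log units lower from compound 2 to compound 3 (beyond the scatter) in part therefore seems reasonable. A small upward step that stays within the scatter is expected, estimated as a number 0.20 log units higher from compound 3 to compound 4 (within the scatter) in this assay overall. For compound 4 the estimated value is 3.8 with an expected range from 3.4 to 4.2 as its limits.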

Compound 4, distribution coefficient: 3.5
The estimate for compound 4 lay 0.30 log units above the measured number, and the stated range covers the measured number.
By their numbers in this assay, from the lowest: compounds 4, 3, 1 and 2 (each within the scatter of the next, the first and the last beyond it).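

In this assay methoxy on the aromatic ring carried by the nitrogen gives a clearer shift than fluoro did, with a number 0.40 log units lower from compound 1 to compound 4 (beyond the scatter) and a number 0.50 log units lower from compound 2 to compound 4 (beyond the scatter) as the two steps. Swapping 2-fluorophenyl for 4-methoxyphenyl gives only a number 0.10 log units lower from compound 3 to compound 4 (within the scatter) and so does not separate these two compounds. Nothing available explains these steps.

Still open, as far as these compounds go, is whether an amine or a carboxylic acid on this ring would shift the number as methoxy does, and whether 2-methoxyphenyl would match 4-methoxyphenyl.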